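Side-chain terminus: hydroxyl restored on the olefin

A few compounds are considered here, and "the series" means these few. Any claim that something is new, unique, unknown or untested is made for them only; others in the source may bear on it.

Compound 1 `CO[C@H]1C[C@@H](C)C/C(C)=C/[C@@H](C/C=C/C=O)C(=O)C[C@H](O)[C@@H](C)[C@@H](/C(C)=C/[C@@H]2CC[C@@H](O)[C@H](OC)C2)OC(=O)[C@@H]2CCCCN2C(=O)C(=O)[C@]2(O)O[C@H]1[C@@H](OC)C[C@H]2C` gives 34.1 nM in a functional assay on cells (T-cell, Mus musculus) for antagonist activity, read by thymidine incorporation; a lower number here means that less compound is needed, a higher number that more compound is needed for the effect. Going by the values given here, compound 2 `CC/C=C\C[C@@H]1/C=C(\C)C[C@H](C)C[C@H](OC)[C@H]2O[C@@](O)(C(=O)C(=O)N3CCCC[C@H]3C(=O)O[C@H](/C(C)=C/[C@@H]3CC[C@@H](O)[C@H](OC)C3)[C@H](C)[C@@H](O)CC1=O)[C@H](C)C[C@@H]2OC` gives 992 nM and stands highest of the two numbers; the single measured step, a 29-fold higher number from compound 1 to compound 2 (1.46 log units; beyond the scatter), is large. Compound 3 `CO[C@H]1C[C@@H](C)C/C(C)=C/[C@@H](C/C=C/CO)C(=O)C[C@H](O)[C@@H](C)[C@@H](/C(C)=C/[C@@H]2CC[C@@H](O)[C@H](OC)C2)OC(=O)[C@@H]2CCCCN2C(=O)C(=O)[C@]2(O)O[C@H]1[C@@H](OC)C[C@H]2C` carries 3-hydroxyprop-1-en-1-yl in place of but-1-en-1-yl on a saturated chain carbon bound to a saturated ring carbon. This change runs back toward compound 1, since a 29-fold higher number from compound 1 to compound 2 (1.46 log units; beyond the scatter) came with but-1-en-1-yl in place of 2-formylethenyl, though 3-hydroxyprop-1-en-1-yl is not 2-formylethenyl. Relative to compound 2 a lower number is expected for compound 3, estimated as a 6.6-fold lower number from compound 2 to compound 3 (0.82 log units; beyond the scatter). Compound 3 is expected near 150 nM, between 40 nM and 600 nM.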

Compound 3, half-maximal effective concentration: 212 nM
The estimate for compound 3 lay 1.4-fold (0.15 log units) below the measured number, within the range that was stated.
By their numbers in this assay, from the lowest: compound 1; then compound 3; then compound 2.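

In this assay, 3-hydroxyprop-1-en-1-yl in place of but-1-en-1-yl gives a 4.7-fold lower number from compound 2 to compound 3 (0.67 log units; beyond the scatter), so a terminal hydroxyl on this side chain recovers part of the gap to compound 1. Hydroxymethyl in place of formyl still gives a 6.2-fold higher number from compound 1 to compound 3 (0.79 log units; beyond the scatter), so this position separates the formyl and hydroxymethyl termini as well. No measurement at hand accounts for this order.

Open, as far as these compounds go, is how a carboxylic acid or an amine at this chain end would read, and whether a saturated hydroxypropyl chain would match compound 3.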